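Chain Length at the Benzylic Amine in a Cytotoxicity Series

A few compounds are considered here, and "the series" means these few. Any claim that something is new, unique, unknown or untested is made for them only; others in the source may bear on it.

Measured compounds:
compound 1 `CC1(C)CCc2c(ccc(CNCc3ccccc3)c2O)O1` gives 60000 nM
compound 2 `CC1(C)CCc2c(ccc(CNCCCc3ccccc3)c2O)O1` gives 27000 nM
compound 3 `CC1(C)C=Cc2cc(CNCc3ccccc3)c(O)cc2O1` gives 57000 nM

All three values come from a toxicity assay on L6 cells (Rattus norvegicus) for inhibition, read by microscopy and resazurin assay, with a stated time of 70 h; on this read-out higher numbers stand for weaker inhibition and lower numbers for stronger inhibition. Compound 1 and compound 3 share the same benzylamine side chain on different cores; the difference between the two cores is not broken down here, and their values lie within the scatter of each other. Compound 2 differs from compound 1 by phenethyl in place of phenyl on a saturated chain carbon bound to an amine nitrogen, and in this assay that change gave a 2.2-fold lower number from compound 1 to compound 2 (0.35 log units; beyond the scatter).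

Compound 4 `CC1(C)C=Cc2cc(CNCCCc3ccccc3)c(O)cc2O1` has not yet been measured. It differs from compound 3 by phenethyl in place of phenyl on a saturated chain carbon bound to an amine nitrogen, at the same place as the change from compound 1 to compound 2, so it is the same change carried over to the other core. Since compound 3 and compound 1 sit close in this assay, the step is expected to be of similar size: for compound 4 the expected step is a 2.0-fold lower number from compound 3 to compound 4 (0.31 log units; beyond the scatter), resting on compound 2 having shown a 2.2-fold lower number from compound 1 to compound 2 (0.35 log units; beyond the scatter). Compound 4 is therefore estimated at 28000 nM, with an expected range from 14000 nM to 60000 nM.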

Compound 4, half-maximal inhibitory concentration: 28000 nM
Compound 4: the middle estimate sits on the measured number at the digits printed, and the stated range covers the measured number.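

In this assay, phenethyl in place of phenyl on a saturated chain carbon bound to an amine nitrogen gave a 2.0-fold lower number from compound 3 to compound 4 (0.31 log units; beyond the scatter), so the change carried over to the second core with its size kept. Set side by side, the two steps do not differ beyond what repeated measurements would give: the same change on two cores in this assay, a 2.2-fold lower number (0.35 log units; beyond the scatter) from compound 1 to compound 2 and a 2.0-fold lower number (0.31 log units; beyond the scatter) from compound 3 to compound 4, 1.1-fold (0.04 log units) apart, within the scatter of two such steps. Going by these compounds alone, this shows that the change behaves alike on these two cores, but it rests on only two pairs of compounds and does not show that the step would hold on any further core, nor does it explain why the number falls.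

The compounds shown leave open whether the number keeps falling with a longer chain than phenethyl, or whether it stops changing or turns back. They also leave open what a pyridine ring in place of the benzene ring of the side chain, or an amide in place of the amine, would do on either core.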